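This account rests on a few compounds, and the source may have more. Where it says the series, first, only, none or still open, it means among the compounds named here.

Within the data shown here, compound 1, `CCCC(=O)c1c(OC)c(Cl)c(OC)c(Cl)c1OC`, is the only compound with a definite number in an ADME assay on the whole organism (strain S2) for cytotoxicity, with Drosophila as the target, read by WST assay; on this read-out lower numbers stand for higher toxicity in this test and higher numbers for lower toxicity in this test; in this assay compound 1 gives 144000 nM. Compound 2, `CCCC(=O)c1c(O)c(Cl)c(O)c(Cl)c1O`, reaches only a limit of the assay, and in this assay compound 2 gives > 100000 nM. No step between two measured compounds is shown. Compound 3, `CCCCCC(=O)c1c(OC)c(Cl)c(OC)c(Cl)c1OC`, differs from compound 1 by ethyl in place of hydrogen on a saturated chain carbon, three bonds along the chain from a carbonyl carbon. For compound 3 a modest step toward higher toxicity is expected, a 1.8-fold lower number from compound 1 to compound 3 (0.26 log units; within the scatter), though it may not exceed the scatter. Compound 3 is therefore estimated at 80000 nM, expected to lie between 30000 nM and 200000 nM.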

Compound 3, half-maximal cytotoxic concentration: 148000 nM
Compound 3: the middle estimate sits 1.9-fold (0.27 log units) below what was measured; the range from low to high includes it.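

In this assay, ethyl in place of hydrogen on a saturated chain carbon, three bonds along the chain from a carbonyl carbon, gives a 1.0-fold higher number from compound 1 to compound 3 (0.01 log units; within the scatter), so at this position the added ethyl makes no difference beyond the scatter. Among these compounds, this is the first step between two measured compounds that can be read. Compound 2 still offers only a limit of the assay, not a number: the limit of > 100000 nM in this assay, at which 1 of the 3 values shown sits. From the compounds shown here alone, whether a much longer chain, or an amine or a carboxylic acid at the chain end, would shift the read-out stays open.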